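This account rests on a few compounds, and the source may have more. Where it says the series, first, only, none or still open, it means among the compounds named here.

Measured so far in a functional assay on A2780 cells (Homo sapiens) for inhibition; a higher number here means a weaker inhibitor, a lower number a stronger inhibitor:
compound 1 `CCNC(=O)c1noc(-c2cc(C(C)C)c(O)cc2O)c1-c1cc(CN)no1` gives "not determined" (no result reported)
compound 2 `CCNC(=O)c1noc(-c2cc(C(C)C)c(O)cc2O)c1-c1cc(C(=O)OCC)no1` gives 9000 nM
compound 3 `CCNC(=O)c1noc(-c2cc(C(C)C)c(O)cc2O)c1-c1cc[nH]n1` gives 33 nM

Compound 3 at 33 nM holds the lower of the two numbers available, and compound 1 offers no number for comparison. Next in line is compound 4 `CCNC(=O)c1noc(-c2cc(C(C)C)c(O)cc2O)c1-c1cnn(C(C)C)c1` with this change: 1-isopropyl-1H-pyrazol-4-yl in place of 1H-pyrazol-3-yl on an aromatic carbon. The change sits on an aromatic carbon, next to the ring atom that bears an ethylcarbamoyl group. Going by the values given here, only one measured step bears on it: a 270-fold lower number from compound 2 to compound 3 (2.44 log units; beyond the scatter) at this same place. That single step shows that exchanging the group here can move the number a long way, but it involves a different group and gives no direct measure for a pyrazole carrying an isopropyl group. Among the compounds with values here, no measured compound isolates the attachment point, the isopropyl group or the loss of the donor. A moderate rise is therefore expected, much smaller than the measured step, with a fall not excluded. Expected is a 2.7-fold higher number from compound 3 to compound 4 (0.44 log units; beyond the scatter) in this assay as a working figure. For compound 4 the estimate is 90 nM in this assay, with an expected range from 15 nM to 550 nM for repeat measurements.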

Compound 4, half-maximal inhibitory concentration: 21 nM
Estimate against measurement, compound 4: 4.3-fold (0.63 log units) above, within the range that was stated.
By their numbers in this assay, from the lowest: compounds 4 and 3 (each within the scatter of the next); then compound 2.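

In this assay the exchange gives a 1.6-fold lower number from compound 3 to compound 4 (0.20 log units; within the scatter) and so stays within the scatter: at this aromatic carbon, 1-isopropyl-1H-pyrazol-4-yl and 1H-pyrazol-3-yl cannot be told apart. The entering group has 8 heavy atoms and 0 hydrogen-bond donors, against 5 heavy atoms and 1 donor in the leaving group, so for these two compounds neither the larger group nor the absence of a donor comes with a change beyond the scatter. Against the ester series member, the new group gives a 430-fold lower number from compound 2 to compound 4 (2.63 log units; beyond the scatter), beyond the scatter, which shows that the large gap seen earlier is not confined to the 1H-pyrazol-3-yl group.

Still open, going by these compounds, is how the attachment point and the isopropyl group each contribute, as they change together in this step and may offset one another. Also open, on these data alone, is what a longer chain in place of the isopropyl group, or a carboxylic acid in place of the ethyl ester of compound 2, would do at this position.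

No measurement offers an explanation for these steps.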